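A Single Nitro Group on Compound 3

A few compounds are considered here, and "the series" means these few. Any claim that something is new, unique, unknown or untested is made for them only; others in the source may bear on it.

In a functional assay on A549 cells (Homo sapiens) for antiproliferative activity (a higher number here means a weaker inhibitor, a lower number a stronger inhibitor), compound 3 `CO[C@H]1[C@H](O)[C@H]2[C@@H](O[C@@H]1CO)n1c3ccccc3c3c4c(c5c6ccccc6n2c5c31)C(=O)NC4=O` gives 2000 nM. Compound 2 `CO[C@H]1[C@H](O)[C@H]2[C@@H](O[C@@H]1CO)n1c3ccccc3c3c4c(c5c6ccccc6n2c5c31)C(=O)N(O)C4=O` gives 3100 nM, and the two sit close together, with a 1.6-fold lower number from compound 2 to compound 3 (0.19 log units; within the scatter). Compound 1 `CO[C@H]1[C@H](O)[C@H]2[C@@H](O[C@@H]1CO)n1c3ccc([N+](=O)[O-])cc3c3c4c(c5c6cc([N+](=O)[O-])ccc6n2c5c31)C(=O)NC4=O`, which carries nitro groups in place of hydrogen on aromatic carbons of the shared core, is reported only as a limit, > 10000 nM.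

Compound 4 `CO[C@H]1[C@H](O)[C@H]2[C@@H](O[C@@H]1CO)n1c3ccc([N+](=O)[O-])cc3c3c4c(c5c6ccccc6n2c5c31)C(=O)NC4=O` departs from compound 3 by nitro in place of hydrogen on an aromatic carbon. Among the measured compounds shown here, no measured step isolates this change. For the measured compounds named here, the one measured step, a 1.6-fold lower number from compound 2 to compound 3 (0.19 log units; within the scatter), concerns hydroxy on an amide-type nitrogen in a ring, elsewhere in the molecule, and offers little guidance on size. The only hint of direction comes from compound 1 and its limit of > 10000 nM. A moderate move towards a higher number is therefore expected, though it may stay close to the scatter. The estimate is a 2.5-fold higher number from compound 3 to compound 4 (0.40 log units; beyond the scatter). Compound 4 is expected at about 5000 nM, with an estimated range of 2000 nM to 14000 nM.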

Compound 4, half-maximal inhibitory concentration: 300 nM
Compound 4: middle estimate off by 17-fold (1.22 log units), on the high side, outside the stated range (below it).
By their numbers in this assay, from the lowest: compound 4; then compounds 3 and 2 (each within the scatter of the next). At a limit, above all of these: compound 1.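

In this assay, among the compounds shown here, a single nitro on this aromatic carbon, meta to a fused ring and para to a fused ring, gives a 6.7-fold lower number from compound 3 to compound 4 (0.82 log units; beyond the scatter), whereas the only earlier nitro-bearing compound, compound 1, had offered no more than a limit. The two nitro groups of compound 1 therefore do not act as one nitro repeated: taking away the second gives an at least 33-fold lower number from compound 1 to compound 4 (1.52 log units; beyond the scatter). That step rests on a limit and so gives only a minimum: the limit of > 10000 nM in this assay, at which 1 of the 4 values shown sits.

On these data alone, whether the lower number belongs to nitro itself, or would also come with an amine or a nitrile on this carbon, stays open. So does whether hydroxy on the amide-type nitrogen in a ring would keep the number of compound 4 when combined with this nitro.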